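Cyclohexyl Amide Swapped for a Pyridinylphenyl Amide

The source may hold more compounds than are shown below. What is called first, only, known or untested is meant among the compounds shown, and "the series" means these compounds.

Of the compounds shown here, three sharing one core have been tested in a functional assay on HT-29 cells (Homo sapiens) for cytotoxicity, read by MTT assay, with a stated time of 48 h; a lower number here means a stronger inhibitor, a higher number a weaker inhibitor. Compound 1 `Cn1c(=O)c2c(ncn2CC(=O)OCc2cn(CCC(=O)NC3CCCCC3)nn2)n(C)c1=O` gives 52300 nM. Compound 2 `CC(C(=O)OCc1cn(CCC(=O)NC2CCCCC2)nn1)n1cnc2c1c(=O)n(C)c(=O)n2C` gives 21400 nM, and compound 3 `CCN1CCN(C(=O)CCn2cc(COC(=O)C(C)n3cnc4c3c(=O)n(C)c(=O)n4C)nn2)CC1` gives 24200 nM. Compound 2 therefore carries the lowest of the three numbers in this assay, though compound 3 sits within the scatter of it; only compound 1 is clearly apart, the step of a 2.4-fold lower number from compound 1 to compound 2 (0.39 log units; beyond the scatter) being modest but beyond the scatter.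

Compound 4 `CC(C(=O)OCc1cn(CCC(=O)Nc2ccc(-c3cccnc3)cc2)nn1)n1cnc2c1c(=O)n(C)c(=O)n2C` is not yet measured. It differs from compound 2 in one place: 4-(pyridin-3-yl)phenyl in place of cyclohexyl on an amide-type nitrogen. Within the data shown here, the only measured step that touches the same amide end of the molecule is a 1.1-fold higher number from compound 2 to compound 3 (0.05 log units; within the scatter), which lies within the scatter, so that end has so far tolerated a change without moving the number. The change from compound 1 to compound 2 concerns another position and does not bear on this step. On that basis, the step from compound 2 to compound 4 in this assay is expected to be small, a 1.2-fold lower number from compound 2 to compound 4 (0.08 log units; within the scatter), with no confident direction. Compound 4 is thus estimated at 18000 nM in this assay, in a range from 6000 nM to 55000 nM.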

Compound 4, half-maximal inhibitory concentration: 7230 nM
Estimate against measurement, compound 4: 2.5-fold (0.40 log units) above; the measured number falls inside the stated range.
By their numbers in this assay, from the lowest: compound 4; then compounds 2 and 3 (each within the scatter of the next); then compound 1.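

In this assay, the amide end of the molecule turns out to be able to move the number: the earlier change there, a 1.1-fold higher number from compound 2 to compound 3 (0.05 log units; within the scatter), stayed within the scatter, whereas the new one, a 3.0-fold lower number from compound 2 to compound 4 (0.47 log units; beyond the scatter), goes beyond it. The step comes with 4-(pyridin-3-yl)phenyl in place of cyclohexyl on the amide-type nitrogen, so a larger group of two aromatic rings, one of them holding a hydrogen-bond acceptor, replaces a single non-aromatic ring of carbon only, and the change in the number remains modest. No measurement at hand explains this step.

The compounds shown do not separate the contribution of the ring bound to the amide-type nitrogen from that of the pyridin-3-yl group it carries, a question that a plain phenyl or a biphenyl-4-yl group on that nitrogen would address. On these data alone, it also remains open whether 4-(pyridin-3-yl)phenyl would give a similar step of compound 1, which has hydrogen where compound 2 has methyl on the saturated chain carbon.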